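This account rests on a few compounds, and the source may have more. Where it says the series, first, only, none or still open, it means among the compounds named here.

Two compounds measured in a functional assay on K562 cells (Homo sapiens) for inhibition, read by MTT assay, with a stated time of 48 h (on this read-out higher numbers stand for weaker inhibition and lower numbers for stronger inhibition), so far
- Compound 1 `CC(=O)Nc1ccc(-c2cn([C@@H]3CN[C@H](C(=O)Nc4ccc(Cl)c(C(F)(F)F)c4)C3)nn2)cn1` gives 8980 nM
- Compound 2 `CCN1CCN(c2cc(NC(=O)[C@@H]3C[C@H](n4cc(-c5ccc6c(N)n[nH]c6c5)nn4)CN3)ccc2Cl)CC1` gives 180 nM

Compound 1 has the higher of the two numbers, which marks weaker inhibition, and its gap to compound 2 lies beyond the usual scatter. Compound 3 `Nc1nc2ccc(-c3cn([C@@H]4CN[C@H](C(=O)Nc5ccc(Cl)c(C(F)(F)F)c5)C4)nn3)nc2s1` changes compound 1 in one place, on an aromatic carbon, where the 6-acetamidopyridin-3-yl group leaves: a group of 10 heavy atoms (6 carbon, 3 nitrogen, 1 sulfur; one five-membered aromatic ring with 2 hetero atoms, one six-membered aromatic ring with 1 hetero atom) in place of a group of 10 heavy atoms (7 carbon, 2 nitrogen, 1 oxygen; one six-membered aromatic ring with 1 hetero atom), on an aromatic carbon. Among the measured compounds shown here, no measured step shows this change. Compound 2 sits at 180 nM but differs from compound 1 in more than one place, so it is only a loose guide. A moderate step towards a lower number in this assay is expected, estimated as a 3.6-fold lower number from compound 1 to compound 3 (0.56 log units; beyond the scatter). For compound 3 the estimated value is 2500 nM, with an expected range from 500 nM to 10000 nM.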

Compound 3, half-maximal inhibitory concentration: 26200 nM
Compound 3: the middle estimate sits 10-fold (1.02 log units) below what was measured; the measured number lies above the stated range.
By their numbers in this assay, from the lowest: compound 2; then compound 1; then compound 3.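

In this assay, replacing the 6-acetamidopyridin-3-yl group with a two-ring group containing sulfur, on the aromatic carbon of the five-membered ring with 3 nitrogen, gives a 2.9-fold higher number from compound 1 to compound 3 (0.47 log units; beyond the scatter), which means weaker inhibition. The number at this position therefore depends on the group it carries, and keeping the same heavy-atom count while adding a second aromatic ring does not bring stronger inhibition. Nothing available here explains this step.

As far as these compounds go, whether a plain phenyl ring or a carboxylic acid on this carbon would give a lower number than compound 1 remains open.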